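A few compounds are considered here, and "the series" means these few. Any claim that something is new, unique, unknown or untested is made for them only; others in the source may bear on it.

In a functional assay on A-375 cells (Homo sapiens) for activation, with a stated time of 3 days (a lower number here means that less compound is needed, a higher number that more compound is needed for the effect), compound 1 `O=C(Nc1ccc(-c2cscn2)cc1)C1CCCN(Cc2cc(F)cc(F)c2)C1` gives 1500 nM, while compound 2 `O=C(Nc1ccc(-c2cscn2)cc1)C1CCCN(Cc2cccc(F)c2F)C1` gives 10000 nM, the higher of the two numbers. Compound 3 `O=C(Nc1ccc(-c2cscn2)cc1)C1CCCN(Cc2ccc(Cl)c(Cl)c2)C1` carries 3,4-dichlorophenyl in place of 2,3-difluorophenyl on a saturated chain carbon bound to an amine nitrogen in a ring. For the measured compounds named here, only one measured step bears on this change: a 6.7-fold higher number from compound 1 to compound 2 (0.82 log units; beyond the scatter), which involved the same group. This single step is thin support, but it points to a modest move towards a lower number. The expected change is a 3.3-fold lower number from compound 2 to compound 3 (0.52 log units; beyond the scatter). For compound 3, the estimated value is 3000 nM, with an expected range of 800 nM to 11000 nM.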

Compound 3, half-maximal effective concentration: 3000 nM
Compound 3: middle estimate and measured number agree at the digits printed; measured number inside the range.
By their numbers in this assay, from the lowest: compounds 1 and 3 (each within the scatter of the next); then compound 2.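

In this assay, the step to 3,4-dichlorophenyl is a 3.3-fold lower number from compound 2 to compound 3 (0.52 log units; beyond the scatter), so this position accepts a phenyl carrying two chlorines as well as one carrying two fluorines. With a 2.0-fold higher number from compound 1 to compound 3 (0.30 log units; within the scatter), 3,4-dichlorophenyl and 3,5-difluorophenyl cannot be told apart, which leaves compound 2 alone at the high end of the three. No measurement available here explains these differences. The change to compound 3 alters both the halogen and its ring positions, so the two effects cannot be separated. Going by these compounds, how a methoxy group or a nitrile on this phenyl would behave remains open.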